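From one aryl amide to another: expectation for compound 4

The source may hold more compounds than are shown below. What is called first, only, known or untested is meant among the compounds shown, and "the series" means these compounds.

Compound 1 `CNC(=O)c1nc(-c2cc(OC)c(OC)c(OC)c2)n(-c2ccc(OC)cc2)n1` gives 74% in a functional assay on the whole organism for inhibition, with Rattus norvegicus as the target, read by paw edema, with stated times of 30 min and 2 h, at a dose of 0.28 mmol/kg by the oral route; a higher number here means more inhibition at the dose given (going by the name of the read-out), a lower number less inhibition.
Compound 2 `COc1ccc(-n2nc(C(=O)Nc3ccccc3OC)nc2-c2cc(OC)c(OC)c(OC)c2)cc1` gives 57% in this assay.
Compound 3 `COc1ccc(-n2nc(C(=O)Nc3ccc(C)cc3)nc2-c2cc(OC)c(OC)c(OC)c2)cc1` gives 60% in this assay.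

Among these three numbers compound 3 stands second highest. Its nearest neighbour is compound 2, and the pair differ by a number 3 percentage points higher from compound 2 to compound 3 (within the scatter), which lies within the scatter. Its furthest neighbour is compound 1, with the gap a number 14 percentage points lower from compound 1 to compound 3 (beyond the scatter), which lies beyond the scatter, as does a number 17 percentage points lower from compound 1 to compound 2 (beyond the scatter).

The unmeasured compound 4 `COc1ccc(-n2nc(C(=O)Nc3cccc(F)c3)nc2-c2cc(OC)c(OC)c(OC)c2)cc1` differs from compound 3 in one place: 3-fluorophenyl in place of 4-methylphenyl on an amide-type nitrogen. The step that bears most directly on this is the one between the two aryl amides, compound 2 and compound 3, because a number 3 percentage points higher from compound 2 to compound 3 (within the scatter) was within the scatter. Both steps away from the methyl amide of compound 1 were modest and downward, and compound 4 keeps an aryl amide, so a change expected to stay within the scatter is a number 2 percentage points lower from compound 3 to compound 4 (within the scatter). Compound 4 is therefore estimated at 58%, with a range from 46% to 70%.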

Compound 4, a percentage reported as inhibition, in the whole organism at one dose (the size of the read-out at that dose, not a potency): 67%
For compound 4 the middle estimate is 9 percentage points below the measured one; low and high end bracket the measured number.
By their numbers in this assay, from the lowest: compounds 2, 3, 4 and 1 (each within the scatter of the next, the first and the last beyond it).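

In this assay, 3-fluorophenyl in place of 4-methylphenyl on the amide-type nitrogen gives a number 7 percentage points higher from compound 3 to compound 4 (within the scatter), and 3-fluorophenyl in place of 2-methoxyphenyl gives a number 10 percentage points higher from compound 2 to compound 4 (within the scatter), so this assay does not separate these three aryl amides by a step beyond the scatter. What is new is a number 7 percentage points lower from compound 1 to compound 4 (within the scatter): compound 2 and compound 3 both lay beyond the scatter from the methyl amide, so an aryl group on this nitrogen does not always bring such a drop. Nothing available offers an explanation for this result.

The compounds shown leave open how 4-fluorophenyl, or an aryl ring carrying an amine or a carboxylic acid, would read at this nitrogen. They also leave open whether a longer chain such as butyl, in place of methyl, would hold the number near that of compound 1.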